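A few compounds are considered here, and "the series" means these few. Any claim that something is new, unique, unknown or untested is made for them only; others in the source may bear on it.

Measured in a functional assay (Platelet, plasma) for inhibition, with Homo sapiens as the target; on this read-out higher numbers stand for weaker inhibition and lower numbers for stronger inhibition:
- Compound 1 `CC1(C(=O)NS(=O)(=O)Cc2ccc(F)cc2)CCN(c2nc3c(cc2C#N)C(=O)OC3)CC1`: 35400 nM
- Compound 2 `N#Cc1cc2c(nc1N1CCC(C(=O)NS(=O)(=O)Cc3ccc(F)cc3)CC1)COC2=O`: 3500 nM

Of these two, compound 1 has the higher number and is the weaker inhibitor. Compound 3 `CC1(C(=O)NS(=O)(=O)Cc2ccc(F)cc2F)CCN(c2nc3c(cc2C#N)C(=O)OC3)CC1` differs from compound 1 in one place: fluoro in place of hydrogen on an aromatic carbon. In other words, 4-fluorobenzyl becomes 2,4-difluorobenzyl.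

Among the compounds with values here, only one measured step is available, a 10-fold lower number from compound 1 to compound 2 (1.00 log units; beyond the scatter), which is modest but beyond the scatter. That step is hydrogen in place of methyl on a saturated ring carbon, so it is a different change from fluoro in place of hydrogen on an aromatic carbon. Within the data shown here, no measured step covers this fluoro change, so no shift beyond the scatter is expected in this assay, in either direction. The expected step is small, a 1.2-fold lower number from compound 1 to compound 3 (0.07 log units; within the scatter). For compound 3 the estimated value is 30000 nM, with an expected range from 10000 nM to 80000 nM.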

Compound 3, half-maximal inhibitory concentration: 8760 nM
Estimate against measurement, compound 3: 3.4-fold (0.53 log units) above; the measured number lies below the stated range.
By their numbers in this assay, from the lowest: compound 2; then compound 3; then compound 1.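

The step from 4-fluorobenzyl to 2,4-difluorobenzyl gives a 4.0-fold lower number from compound 1 to compound 3 (0.61 log units; beyond the scatter) in this assay, so the aromatic ring of the benzyl group also bears on this read-out, not only the saturated ring carbon changed in the earlier step. One fluoro, a single heavy atom placed ortho to a large group and meta to the existing fluoro group, is enough for a shift beyond the scatter. Nothing available explains why this change has such an effect.

The compounds shown leave open whether this step and a 10-fold lower number from compound 1 to compound 2 (1.00 log units; beyond the scatter) would add up in one compound joining 2,4-difluorobenzyl with hydrogen in place of methyl. They also leave open whether the shift is particular to fluoro, or whether chloro, methyl or methoxy at the same place would give a similar one.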